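The source may report more compounds than this note shows. Statements on the series, on what has been measured and on what is new or still open speak of the compounds shown alone.

Measured so far in a functional assay on HeLa cells (Homo sapiens) for antiproliferative activity, read by MTT assay, with a stated time of 72 h (a higher number here means a weaker inhibitor, a lower number a stronger inhibitor), are three compounds.
- Compound 1 `COc1cccc(N2C(=O)COc3ccc(-c4cnc5ccccc5c4)cc32)c1` gives 11400 nM as its value.
- Compound 2 `CC(C)N1C(=O)COc2ccc(-c3cccc(NS(=O)(=O)c4ccc(F)cc4)c3)cc21` gives 22700 nM as its value.
- Compound 3 `O=C1COc2ccc(-c3cnc4ccccc4c3)cc2N1` gives > 40000 nM as a limit of the assay, not a number.

Compound 2 and compound 1 lie within the usual scatter of each other in this assay so neither can be ranked above the other. Among the compounds with values here, compound 4 `Cc1ccc(N2C(=O)COc3ccc(-c4cccc(NS(=O)(=O)c5ccc(F)cc5)c4)cc32)cc1` keeps the rest of compound 2 but has 4-methylphenyl in place of isopropyl on an amide-type nitrogen in a ring as its only change.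

Within the data shown here, one measured step touches that nitrogen, and it puts hydrogen in place of 3-methoxyphenyl (an at least 3.5-fold higher number from compound 1 to compound 3 (0.54 log units; beyond the scatter)) with a result beyond the scatter. That step is only a loose guide, since it does not involve isopropyl and compound 1 also differs from compound 2 elsewhere. A modest move to a lower number is therefore expected, as the estimated step (a 2.5-fold lower number from compound 2 to compound 4 (0.40 log units; beyond the scatter)) shows. Compound 4 is expected at 9000 nM with an estimated range from 2500 nM to 30000 nM in this measurement.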

Compound 4, half-maximal inhibitory concentration: > 40000 nM
Compound 4: no number, only a limit; the forecaster's own chance of this, stated with the estimate: 15%; at least 4.4-fold (0.64 log units) between middle value and limit.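

In this assay, putting 4-methylphenyl in place of isopropyl on the amide-type nitrogen gives an at least 1.7-fold higher number from compound 2 to compound 4 (0.24 log units; that floor lies within the scatter), so this change brings no lower number, although that floor alone does not separate the two compounds. The earlier step, an at least 3.5-fold higher number from compound 1 to compound 3 (0.54 log units; beyond the scatter), had linked a phenyl ring on this nitrogen with a lower number, but compounds 2 and 4 show that such a ring does not bring one in every case. The true size of the new step cannot be read, since it rests on a limit of the assay and not on a number: the limit of > 40000 nM in this assay, at which 2 of the 4 values shown sit.

Going by these compounds, it stays open whether a longer chain, such as n-butyl, or a chain ending in an amine would give a lower number than isopropyl on this nitrogen. A carboxylic acid at the end of such a chain is equally untested among the compounds shown.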